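Adding a second chloro on a shared core

This account rests on a few compounds, and the source may have more. Where it says the series, first, only, none or still open, it means among the compounds named here.

Measured compounds:
Compound 1, `ClCc1cccc(Cn2cnc3ncnc(Cl)c32)c1`, gives 2630 nM in a functional assay on COLO 205 cells (Homo sapiens) for cytotoxicity, read by sulforhodamine B assay, with a stated time of 48 h; a lower number here means a stronger inhibitor of growth, a higher number a weaker inhibitor of growth.
Compound 2, `ClCc1ccccc1Cn1cnc2ncnc(Cl)c21`, gives 4360 nM in this assay.
Compound 3, `ClCc1cccc(Cn2cnc3nc(Cl)nc(Cl)c32)c1`, gives 410 nM in this assay.

Compounds 1 and 2 have the same atoms joined differently; the difference between the two cores is not broken down here. Their two values lie within the scatter of each other, so nothing can be said about their order. Compound 3 arises from compound 1 by chloro in place of hydrogen on an aromatic carbon, and that step gave a 6.4-fold lower number from compound 1 to compound 3 (0.81 log units; beyond the scatter).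

Compound 4, `ClCc1ccccc1Cn1cnc2nc(Cl)nc(Cl)c21`, is not yet measured. Going by the values given here, it arises from compound 2 by chloro in place of hydrogen on an aromatic carbon, which is the same change, at a place described in the same words, as the one that led from compound 1 to compound 3. Because the step of a 6.4-fold lower number from compound 1 to compound 3 (0.81 log units; beyond the scatter) was clearly beyond the scatter, a step of similar size is expected here too, so that for compound 4 the expected step is a 5.8-fold lower number from compound 2 to compound 4 (0.76 log units; beyond the scatter) in this assay. The estimate for compound 4 in this assay is 750 nM, with a range from 300 nM to 2000 nM.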

Compound 4, concentration for 50% growth inhibition: 350 nM
Compound 4: middle estimate off by 2.1-fold (0.33 log units), on the high side, and the stated range covers the measured number.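

Putting chloro in place of hydrogen on the aromatic carbon between two ring nitrogen atoms gave a 12-fold lower number from compound 2 to compound 4 (1.10 log units; beyond the scatter) in this assay, so this step is large and lies well outside ordinary assay variation. The same change lowered the number on both cores, and the two steps cannot be told apart in size: the same change on two cores in this assay, a 6.4-fold lower number (0.81 log units; beyond the scatter) from compound 1 to compound 3 and a 12-fold lower number (1.10 log units; beyond the scatter) from compound 2 to compound 4, 1.9-fold (0.29 log units) apart, within the scatter of two such steps

Going by these compounds alone, this shows that, for these two closely related cores, the effect of the change carried over, and the step on compound 2 should not be read as truly larger than the one on compound 1. It does not show why the number falls, and it does not show that the change would behave the same way on a third core or in a different assay.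

The compounds shown leave open what an amine or a methoxy group would do on that same aromatic carbon in place of chloro. They also leave open whether the chloromethyl group is needed for growth inhibition, which a comparison with a plain methyl group could address.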